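Swapping ethynyl for phenyl on the sulfur-bound chain carbon

A few compounds are considered here, and "the series" means these few. Any claim that something is new, unique, unknown or untested is made for them only; others in the source may bear on it.

Measured compounds, in a functional assay on PC-3M cells (Homo sapiens) for cytotoxicity, read by MTT assay, with a stated time of 48 h; a higher number here means a weaker inhibitor, a lower number a stronger inhibitor:
Compound 1, `Cc1nnc(SCC(=O)c2ccc(Cl)cc2)n1N1C(=O)c2ccccc2C1=O`, gives > 200000 nM, which is a limit of the assay and not a number.
Compound 2, `C#CCSc1nnc(C)n1N1C(=O)c2ccccc2C1=O`, gives > 200000 nM, also a limit.
Compound 3, `C#CCSc1nnc(CC)n1N1C(=O)c2ccccc2C1=O`, gives > 200000 nM, again a limit.

Compound 3 therefore stands at no measured number at all: every value here sits at the same place, namely (the limit of > 200000 nM in this assay, at which 3 of the 3 values shown sit). The two steps among the measured compounds, a step that the two limits leave unreadable from compound 1 to compound 2 and a step that the two limits leave unreadable from compound 2 to compound 3, cannot be read in size because both ends of each sit at the limit of > 200000 nM in this assay, at which 3 of the 3 values shown sit. Going by the values given here, they show only that exchanging the group on the sulfur-bound chain carbon, or lengthening the chain on the aromatic-bound carbon, left no measurable inhibition.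

Compound 4, `CCc1nnc(SCc2ccccc2)n1N1C(=O)c2ccccc2C1=O`, differs from compound 3 by phenyl in place of ethynyl on a saturated chain carbon bound to a sulfur. Among the compounds with values here, no measured step matches this change, and nothing among the three compounds points toward a gain in potency. Compound 4 is expected to show a number no higher from compound 3 to compound 4 (the limit leaves the size open) in this assay, most likely remaining at the limit. The estimate for compound 4 is 200000 nM, in the range 50000 nM to 400000 nM.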

Compound 4, half-maximal inhibitory concentration: > 200000 nM
Compound 4: only a limit was reported; the forecaster's own chance of this, stated with the estimate: 85%; the middle value lies on the limit itself.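

The step from compound 3 to compound 4 cannot be read in size, because both compounds sit at the same limit, which is not a number: the limit of > 200000 nM in this assay, at which 4 of the 4 values shown sit.

The compounds shown leave open whether any change to the shared core would bring a measurable value in this assay at all.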